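Moving a Methoxy Group Within a Series at the Limit

The source may report more compounds than this note shows. Statements on the series, on what has been measured and on what is new or still open speak of the compounds shown alone.

Of the compounds shown here, three sharing one core have been measured in a functional assay on SW-620 cells (Homo sapiens) for antiproliferative activity, read by MTT assay, with a stated time of 72 h; on this read-out lower numbers stand for stronger inhibition and higher numbers for weaker inhibition. Compound 1 `O=C1O/C(=C\Cn2cc(-c3ccc(Br)cc3)nn2)C(OCc2ccccc2)=C1OCc1ccccc1` gives > 100000 nM, which is a limit of the assay and not a number. Compound 2 `Cc1ccc(-c2cn(C/C=C3\OC(=O)C(OCc4ccccc4)=C3OCc3ccccc3)nn2)cc1` gives in this assay > 100000 nM, likewise only a limit. Compound 3 `COc1ccc(-c2cn(C/C=C3\OC(=O)C(OCc4ccccc4)=C3OCc3ccccc3)nn2)cc1` gives in this assay > 100000 nM, again a limit rather than a number. Because all three values sit at the limit of > 100000 nM in this assay, at which 3 of the 3 values shown sit, none of the steps among them can be sized: a step that the two limits leave unreadable from compound 1 to compound 2, a step that the two limits leave unreadable from compound 1 to compound 3 and a step that the two limits leave unreadable from compound 2 to compound 3 are all unreadable. Compound 3 thus stands at the limit together with the other two, and no ordering among the three can be drawn from what is shown.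

Compound 4 `COc1ccccc1-c1cn(C/C=C2\OC(=O)C(OCc3ccccc3)=C2OCc2ccccc2)nn1` differs from compound 3 by 2-methoxyphenyl in place of 4-methoxyphenyl on an aromatic carbon. For the measured compounds named here, the steps that bear on this change concern the same aromatic carbon: a step that the two limits leave unreadable from compound 1 to compound 3 and a step that the two limits leave unreadable from compound 2 to compound 3 each swapped one group for another there, and neither could be read, since both values in each pair sit at the limit. Nothing measured therefore argues for a move away from that limit, and for compound 4 the expected step is a step that the limit leaves unreadable from compound 3 to compound 4, meaning no readable change. Compound 4 is estimated at 200000 nM, between 50000 nM and 1000000 nM, and most likely the assay will again report only a limit.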

Compound 4, half-maximal inhibitory concentration: > 100000 nM
Compound 4 was reported as a limit; the forecaster's own chance of this, stated with the estimate: 85%; the middle value is on the limit's open side.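

The steps from compound 1, compound 2 and compound 3 to compound 4 cannot be read, because compound 4 also gives only a limit in this assay: the limit of > 100000 nM in this assay, at which 4 of the 4 values shown sit.

The compounds shown leave open how 2-methoxyphenyl and 4-methoxyphenyl compare, and whether any compound on the shared core gives a readable number in this assay.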